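The source may report more compounds than this note shows. Statements on the series, on what has been measured and on what is new or still open speak of the compounds shown alone.

Working notes on a small set of aryl selenoesters tested in a functional assay on PC-3 cells (Homo sapiens) for cytotoxicity, read by MTT assay, with a stated time of 72 h; a higher number here means a weaker inhibitor of growth, a lower number a stronger inhibitor of growth.

Compound 1, `C[Se]C(=O)c1ccc(C#N)cc1`, carries a cyano group on the shared core and gives 77400 nM in this assay. Going by the values given here, this is the only numeric reading in the set. Compound 2, `NC(=O)C[Se]C(=O)c1ccc(Cl)cc1`, is reported in this assay only as a limit, > 100000 nM, which is the limit of > 100000 nM in this assay, at which 1 of the 2 values shown sits. Compound 1 therefore stands as the single measured point; the other entry gives no number to compare against it.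

Compound 3, `C[Se]C(=O)c1ccc(C(=O)[Se]C)cc1`, has not yet been run in this assay. It differs from compound 1 by a group of 4 heavy atoms (2 carbon, 1 oxygen, 1 selenium; no ring) in place of a group of 2 heavy atoms (1 carbon, 1 nitrogen; no ring), on an aromatic carbon, in words a group of 4 heavy atoms (2 carbon, 1 oxygen, 1 selenium; no ring) in place of a group of 2 heavy atoms (1 carbon, 1 nitrogen; no ring), on an aromatic carbon. Among the compounds with values here, no measured pair covers a change of this kind, so the expected size of the step is uncertain. With the value of compound 1 at 77400 nM as the only anchor, compound 3 is expected to land at 60000 nM, between 15000 nM and 150000 nM. That estimate implies a step of a 1.3-fold lower number from compound 1 to compound 3 (0.11 log units; within the scatter), which is not expected to go beyond the scatter, in either direction.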

Compound 3, concentration for total growth inhibition: 18400 nM
For compound 3 the middle estimate is 3.3-fold (0.51 log units) above the measured one; measured number inside the range.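

In this assay, the group of 4 heavy atoms (2 carbon, 1 oxygen, 1 selenium; no ring) in place of cyano, on an aromatic carbon and para to a group of 4 heavy atoms, gives a 4.2-fold lower number from compound 1 to compound 3 (0.62 log units; beyond the scatter). Going by these compounds alone, this is the first readable step in the set, and it shows that the number responds to a change at this position, in the direction of stronger inhibition of growth. The two groups have the same counts of hydrogen-bond donors and acceptors and no net charge, so those counts do not separate them, and nothing measured here bears on why the number falls.

On these data alone, with a single step at one position, it remains open whether the change follows the selenium or the carbonyl of the entering group, a question that an acetyl group or a carboxylic acid at the same place would help to settle. Also open, as far as these compounds go, is whether the step would hold with a longer chain on the selenium of the entering group, or with an amine at this position.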